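A methyl added to a compound at the limit

The compounds below may be only part of what the source reports. "The series", "measured", "known", "first", "only" and "open" are said of these compounds alone.

In a functional assay on the whole organism for agonist activity, with Mus musculus as the target (a lower number here means that less compound is needed, a higher number that more compound is needed for the effect), compound 2 (`CCOC(=O)N(C)CC#CCN1CCCC1`) gives > 100 mg/kg, which is a limit of the assay and not a number. Compound 3 (`CCOC(=O)N(C)C(C)C#CCN1CCCC1`) has methyl in place of hydrogen on a saturated chain carbon bound to an amide-type nitrogen and a triple-bonded carbon. Compound 1 (`COC(=O)N(C)C(C)C#CCN1CCCC1`) carries a methyl at that place and gives 14.2 mg/kg. On that ground, an expected step of an at least 3.3-fold lower number from compound 2 to compound 3 (0.52 log units; beyond the scatter) points toward a lower dose, beyond the scatter. Compound 3 is estimated at 30 mg/kg, within an expected range of 8 mg/kg to 100 mg/kg.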

Compound 3, dose for half-maximal effect: > 100 mg/kg
Compound 3: only a limit was reported (the forecaster's own chance of this, stated with the estimate: 20%); middle value at least 3.3-fold (0.52 log units) from the limit.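

In this assay compound 3 gives > 100 mg/kg, which is a limit of the assay and not a number. The effect of the methyl on the saturated chain carbon bound to an amide-type nitrogen and a triple-bonded carbon cannot be read here, because both compounds carrying or lacking it sit at that limit: the limit of > 100 mg/kg in this assay, at which 2 of the 3 values shown sit. Methyl in place of hydrogen on a saturated chain carbon bound to an oxygen next to a carbonyl group gives an at least 7.0-fold higher number from compound 1 to compound 3 (0.84 log units; beyond the scatter), so the chain methyl alone does not secure a readable dose.

As far as these compounds go, what the chain methyl does in a compound that reads inside the assay's range remains open. So does the outcome for a longer chain on that oxygen, or an amine in its place.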